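A few compounds are considered here, and "the series" means these few. Any claim that something is new, unique, unknown or untested is made for them only; others in the source may bear on it.

Three amides that share one core have been tested in a functional assay on SW-620 cells (Homo sapiens) for cytotoxicity, read by MTT assay, with a stated time of 48 h; a higher number here means a weaker inhibitor, a lower number a stronger inhibitor. Compound 1 `CCCCCCCCCCCCNC(=O)[C@@H](NC(=O)c1ccco1)[C@@H](C)O` gives 87500 nM, compound 2 `CCCCCCCCCCCCNC(=O)[C@@H](NC(=O)c1cccs1)[C@@H](C)O` gives 29200 nM, and compound 3 `C/C=C/C=C/C(=O)N[C@H](C(=O)NCCCCCCCCCCCC)[C@@H](C)O` gives 200000 nM, the highest of the three numbers. The steps of a 2.3-fold higher number from compound 1 to compound 3 (0.36 log units; beyond the scatter) and a 6.8-fold higher number from compound 2 to compound 3 (0.84 log units; beyond the scatter) show that putting penta-1,3-dien-1-yl on the carbonyl carbon in place of a ring raised the number each time. Compound 4 `CCCCCCCCCCCCNC(=O)[C@@H](NS(=O)(=O)c1ccc(C)cc1)[C@@H](C)O` differs from compound 3 by (4-methylphenyl)sulfonyl in place of (penta-1,3-dien-1-yl)carbonyl on an amine nitrogen. Among the compounds with values here, a ring again enters where the diene leaves, so a lower number is expected for compound 4, although a sulfonyl group has no measured precedent here, which widens the range. Compound 4 is therefore estimated at 50000 nM (range 12000 nM to 200000 nM), which is expected to be a step of a 4.0-fold lower number from compound 3 to compound 4 (0.60 log units; beyond the scatter).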

Compound 4, half-maximal inhibitory concentration: 25600 nM
Beside the measured number, compound 4's estimate is 2.0-fold (0.29 log units) above it; the measured number falls inside the stated range.
By their numbers in this assay, from the lowest: compounds 4 and 2 (each within the scatter of the next); then compound 1; then compound 3.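

The carbonyl on this amine nitrogen is not needed for a lower number in this assay: (4-methylphenyl)sulfonyl gives a 7.8-fold lower number from compound 3 to compound 4 (0.89 log units; beyond the scatter) and a 3.4-fold lower number from compound 1 to compound 4 (0.53 log units; beyond the scatter) against the diene and furan amides. Against the thiophene amide, the change gives a 1.1-fold lower number from compound 2 to compound 4 (0.06 log units; within the scatter) so a sulfonyl link and a carbonyl link can each reach this level. Still open, going by these compounds, is whether a methanesulfonyl group, or a carboxylic acid in place of the ring's methyl, would keep this level. Nothing available explains why these groups rank as they do.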